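Cathepsin S amide series: azetidine amide variant

This account rests on a few compounds, and the source may have more. Where it says the series, first, only, none or still open, it means among the compounds named here.

Measured so far:
compound 1 `N#CCNC(=O)[C@@H]1CC(F)(F)C[C@H]1C(=O)N1CCOCC1` gives 830 nM
compound 2 `N#CC1(NC(=O)[C@@H]2C[C@@H](S(=O)(=O)c3ccccc3)C[C@H]2C(=O)N2CC3(COC3)C2)CC1` gives 3 nM

Two compounds have numbers in an assay on isolated protein for inhibition of cathepsin S (Homo sapiens), read by fluorescence, with a stated time of 20 min; on this read-out higher numbers stand for weaker inhibition and lower numbers for stronger inhibition. Compound 2 gives the lower of the two, and the gap to compound 1 is well beyond the scatter, so compound 2 is the stronger inhibitor of the pair. Going by the values given here, no single-point step between the two measured compounds is available; the two differ in several places at once.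

Compound 3 `N#CC1(NC(=O)[C@@H]2C[C@@H](S(=O)(=O)c3ccccc3)C[C@H]2C(=O)N2CCC2)CC1` is not yet measured. It differs from compound 2 only on the carbonyl carbon: a group of 4 heavy atoms (3 carbon, 1 nitrogen; one four-membered non-aromatic ring with 1 hetero atom) in place of a group of 7 heavy atoms (5 carbon, 1 nitrogen, 1 oxygen; 2 four-membered non-aromatic rings with 1 hetero atom each), on a carbonyl carbon

With no measured step of this kind in the set, the expectation rests on the closeness of compound 3 to compound 2. The step of a 1.7-fold higher number from compound 2 to compound 3 (0.22 log units; within the scatter) is expected to be small, toward a slightly higher number or none beyond the scatter. Compound 3 is therefore estimated at 5 nM, with a range from 1.5 nM to 15 nM.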

Compound 3, half-maximal inhibitory concentration: 10 nM
Beside the measured number, compound 3's estimate is 2.0-fold (0.30 log units) below it; measured number inside the range.
By their numbers in this assay, from the lowest: compound 2; then compound 3; then compound 1.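

Going by these compounds alone, on the carbonyl carbon, this is the first change that can be read in one place, and it is not silent in this assay: azetidin-1-yl in place of the group of 7 heavy atoms with two four-membered rings gives a modest step (a 3.3-fold higher number from compound 2 to compound 3 (0.52 log units; beyond the scatter)). The simpler azetidin-1-yl group still leaves compound 3 at 10 nM, so the second four-membered ring and its oxygen are not required for a low number on this core. No measurement at hand bears on the origin of this step.

On these data alone, whether the oxygen or the added carbon framework carries the step remains open. As far as these compounds go, it is also open how groups such as pyrrolidin-1-yl, piperidin-1-yl or 3-hydroxyazetidin-1-yl would read on the same carbonyl carbon.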